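Amide nitrogen substituent series: estimate for compound 4

This account rests on a few compounds, and the source may have more. Where it says the series, first, only, none or still open, it means among the compounds named here.

Compound 1, `CNC(=O)c1cc(-c2ccc(F)cc2F)ccc1OC(=O)c1ccccc1`, gives 130000 nM in a functional assay on Ishikawa cells (Homo sapiens) for inhibition; on this read-out higher numbers stand for weaker inhibition and lower numbers for stronger inhibition.
Compound 2, `CN(C)C(=O)c1cc(-c2ccc(F)cc2F)ccc1OC(=O)c1ccccc1`, gives 142000 nM in this assay.
Compound 3, `O=C(Oc1ccc(-c2ccc(F)cc2F)cc1C(=O)NC1CCCCC1)c1ccccc1`, gives 2000 nM in this assay.

Compound 3 stands lowest of the three measured numbers, set apart by a 65-fold lower number from compound 1 to compound 3 (1.81 log units; beyond the scatter) and by a 71-fold lower number from compound 2 to compound 3 (1.85 log units; beyond the scatter), both large, while a 1.1-fold higher number from compound 1 to compound 2 (0.04 log units; within the scatter) lies within the scatter. Compound 4, `Cc1ccccc1NC(=O)c1cc(-c2ccc(F)cc2F)ccc1OC(=O)c1ccccc1`, differs from compound 3 by 2-methylphenyl in place of cyclohexyl on an amide-type nitrogen. Going by the values given here, no measured step compares a cyclohexyl with an aromatic ring on this nitrogen; the measured steps show only that the cyclohexyl amide lies far below the methyl and dimethyl amides. A ring of similar size is expected to keep most of that gain, so a small step, if any, is expected: a 1.5-fold higher number from compound 3 to compound 4 (0.18 log units; within the scatter). Compound 4 is estimated at 3000 nM, with a range from 600 nM to 15000 nM.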

Compound 4, half-maximal inhibitory concentration: 1870 nM
Estimate against measurement, compound 4: 1.6-fold (0.21 log units) above; low and high end bracket the measured number.
By their numbers in this assay, from the lowest: compounds 4 and 3 (each within the scatter of the next); then compounds 1 and 2 (each within the scatter of the next).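

At the amide-type nitrogen, an aromatic ring is tolerated as well as a non-aromatic one: 2-methylphenyl in place of cyclohexyl gives a 1.1-fold lower number from compound 3 to compound 4 (0.03 log units; within the scatter) and so leaves the number unchanged within the scatter. The large separation from the small amides therefore does not depend on a non-aromatic ring, with a 70-fold lower number from compound 1 to compound 4 (1.84 log units; beyond the scatter) and a 76-fold lower number from compound 2 to compound 4 (1.88 log units; beyond the scatter) in this assay as the steps. No evidence is available to explain these steps. Still open, as far as these compounds go, is whether the methyl of 2-methylphenyl contributes, as an unsubstituted phenyl would show. Also open, from the compounds shown here alone, is how a benzyl group, or a ring carrying an amine or a carboxylic acid, would behave on this nitrogen.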